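The compounds below may be only part of what the source reports. "The series", "measured", "known", "first", "only" and "open" are said of these compounds alone.

Compound 1 `CCOC(=O)C1=C(C)NC(/C=C/C#N)=C(C(=O)OCC)C1c1cccc([N+](=O)[O-])c1` gives 45 nM in a functional assay on HEK293 cells for antagonist activity at Voltage-dependent L-type calcium channel subunit alpha-1D (Rattus norvegicus), read by FLIPR; on this read-out higher numbers stand for weaker inhibition and lower numbers for stronger inhibition.
Compound 2 `CCOC(=O)C1=C(C)NC(/C=C/c2ccc([N+](=O)[O-])cc2)=C(C(=O)OCC)C1c1cccc([N+](=O)[O-])c1` gives 2060 nM in this assay.
Compound 3 `C=C(C)CCOC(=O)C1=C(C)NC(C)=C(C(=O)OC)C1c1cccc([N+](=O)[O-])c1` gives 47 nM in this assay.

Compound 3 stands second highest of the three numbers. Its nearest neighbour is compound 1, within the scatter, so no order between the two can be claimed; compound 2 stands far higher, beyond the scatter. For the measured compounds named here, the only step measured between compounds differing in one place is a 46-fold higher number from compound 1 to compound 2 (1.66 log units; beyond the scatter), a large step, but it sits on the double-bonded chain carbon bound to the core, not on an ester.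

Compound 4 `COC(=O)C1=C(C)NC(C)=C(C(=O)OCC(C)[N+](=O)[O-])C1c1cccc([N+](=O)[O-])c1` is not yet measured in this assay. It differs from compound 3 by 1-nitroethyl in place of 2-methylprop-2-en-1-yl on a saturated chain carbon bound to an oxygen next to a carbonyl group. Going by the values given here, no measured step touches the ester chain, so the step from compound 1 to compound 2 is not a direct guide. What the ester variants seen so far show is that compound 1 and compound 3, which differ at the ester as well as at the chain, give values within the scatter of each other. On that basis the expected step is a 1.3-fold higher number from compound 3 to compound 4 (0.11 log units; within the scatter), no change beyond the scatter, with the range kept wide for want of a closer precedent. Compound 4 is estimated at 60 nM, between 15 nM and 250 nM.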

Compound 4, half-maximal inhibitory concentration: 111 nM
The estimate for compound 4 lay 1.9-fold (0.27 log units) below the measured number; low and high end bracket the measured number.
By their numbers in this assay, from the lowest: compounds 1 and 3 (each within the scatter of the next); then compound 4; then compound 2.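

For the compounds shown here, on the saturated chain carbon bound to an oxygen next to a carbonyl group, the swap of 2-methylprop-2-en-1-yl for 1-nitroethyl gives a 2.4-fold higher number from compound 3 to compound 4 (0.37 log units; beyond the scatter) in this assay and thus provides the first direct reading that this ester chain is not silent. The step is modest beside a 46-fold higher number from compound 1 to compound 2 (1.66 log units; beyond the scatter) on the double-bonded chain carbon, so a change at this place can move the number while, in these two single pairs, moving it less than the change on the other chain; two pairs set no rule for either place. The change removes a chain of only carbon and brings in nitrogen and oxygen with two hydrogen-bond acceptors, but nothing available ties the higher number to any one of these differences.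

One pair cannot separate the nitro group from the loss of the 2-methylprop-2-en-1-yl group, and a plain propyl chain at this place would be the closest test of that. From the compounds shown here alone, whether an amine or a carboxylic acid on this chain, or a longer carbon chain, would stay near compound 3 or go further than compound 4 also remains open.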